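The source may hold more compounds than are shown below. What is called first, only, known or untested is meant among the compounds shown, and "the series" means these compounds.

Measured compounds:
Compound 1 `COc1ccc(-c2cn(C[C@H](O)[C@H]3OC(=O)C(OCc4ccccc4)=C3OCc3ccccc3)nn2)cc1` gives 99700 nM in a functional assay on MCF7 cells (Homo sapiens) for antiproliferative activity, read by MTT assay, with a stated time of 72 h; a lower number here means a stronger inhibitor, a higher number a weaker inhibitor.
Compound 2 `COc1ccccc1-c1cn(C[C@H](O)[C@H]2OC(=O)C(OCc3ccccc3)=C2OCc2ccccc2)nn1` gives > 100000 nM in this assay, which is a limit of the assay and not a number.

Within the data shown here, compound 2 therefore stands at the limit of > 100000 nM in this assay, at which 1 of the 2 values shown sits, and its position relative to compound 1 cannot be read as a size; the one measured step is a number no lower from compound 1 to compound 2 (the limit leaves the size open). Compound 1 sits close to that same limit, so the two measured compounds together show only very weak activity across the substituents present.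

Compound 3 `O=C1O[C@H]([C@@H](O)Cn2cc(-c3ccc(Br)cc3)nn2)C(OCc2ccccc2)=C1OCc1ccccc1` is not yet measured. Its change from compound 2 is 4-bromophenyl in place of 2-methoxyphenyl on an aromatic carbon. Among the measured compounds shown here, no measured step shows this change directly; the single measured step bears on it only in that swapping one aryl group for another at this position did not move the number downward, with its size left open. Given that both measured compounds sit at or next to the limit, compound 3 is expected to show a step of an at least 1.1-fold lower number from compound 2 to compound 3 (0.04 log units; that floor lies within the scatter), that is, essentially no movement beyond the scatter. The estimate for compound 3 in this assay is 90000 nM, with a range from 30000 nM to 300000 nM, and a fair chance that only a limit is reported.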

Compound 3, half-maximal inhibitory concentration: 5620 nM
Beside the measured number, compound 3's estimate is 16-fold (1.20 log units) above it; measured number below the stated range.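

The aryl group on the five-membered aromatic ring with 3 nitrogen can move the read-out in this assay well away from the limit region: 4-bromophenyl in place of 2-methoxyphenyl gives an at least 17-fold lower number from compound 2 to compound 3 (1.25 log units; beyond the scatter). The comparison that keeps the 4-substituted phenyl shows the same thing with a readable size, since bromo in place of methoxy gives an 18-fold lower number from compound 1 to compound 3 (1.25 log units; beyond the scatter), so this position responds to the identity of the substituent and not only to where it sits on the phenyl. Compound 2 carries a limit of the assay and not a number, so the step that starts from it is a floor on the size: the limit of > 100000 nM in this assay, at which 1 of the 3 values shown sits.

Three aryl groups cannot show whether the gain belongs to bromo in particular, or what lies behind it; chloro, a nitrile, a carboxylic acid, an amine or a plain unsubstituted phenyl at this place would begin to separate these readings. Also open, as far as these compounds go, are 2-bromophenyl, which would test the substituent's location with bromo held fixed, and whether the gain survives when the benzyl ethers of the shared core are replaced by a smaller group such as methyl.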